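This account rests on a few compounds, and the source may have more. Where it says the series, first, only, none or still open, it means among the compounds named here.

Compound 1, `C=CCOC(=O)Nc1ccc([Se]C#N)cc1`, was tested in a functional assay on HT-29 cells (Homo sapiens) for cytotoxicity, read by MTT assay, with a stated time of 72 h (a higher number here means that more compound is tolerated, a lower number that less compound is tolerated), where compound 1 gives 72800 nM. Of the two numbers at hand this is the lower one, yet the gap to compound 2, `O=C(Nc1ccc([Se][Se]c2ccc(NC(=O)OCc3ccc([N+](=O)[O-])cc3)cc2)cc1)OCc1ccc([N+](=O)[O-])cc1`, lies within the scatter of repeated measurements: in this assay compound 2 gives 75900 nM, so the two compounds cannot be told apart. Within the data shown here, no step between two measured compounds that differ in a single place is available, and the scatter alone sets the frame for any prediction. Compound 3, `CCOC(=O)Nc1ccc([Se]C#N)cc1`, differs from compound 1 by one change: methyl in place of vinyl on a saturated chain carbon bound to an oxygen next to a carbonyl group. Nothing in the measured pair points to a shift in either direction, so the step is expected to remain within the scatter. Compound 3 is therefore estimated at 75000 nM, with a range from 35000 nM to 160000 nM, which means an expected step of a 1.0-fold higher number from compound 1 to compound 3 (0.01 log units; within the scatter).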

Compound 3, concentration lethal to 50% of the cells: 66600 nM
Compound 3: the middle estimate sits 1.1-fold (0.05 log units) above what was measured; the range from low to high includes it.
By their numbers in this assay, from the lowest: compounds 3, 1 and 2 (each within the scatter of the next).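

Among these compounds, the step of a 1.1-fold lower number from compound 1 to compound 3 (0.04 log units; within the scatter) in this assay is the first comparison here of two compounds that differ in one place. It shows that, on a saturated chain carbon bound to an oxygen next to a carbonyl group, methyl in place of vinyl, the same difference as allyloxy to ethoxy, gives no change that can be told from the scatter. Losing the double bond outside aromatic rings and one carbon therefore leaves no readable mark on the number for this shared core.

Going by these compounds, only allyl and ethyl are compared at this place, so it remains open whether a longer chain would also leave the number unmoved. The same holds for an amine or a carboxylic acid at the end of the chain. No measurement at hand offers an explanation for this result.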